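One group swapped on compound 2

This account rests on a few compounds, and the source may have more. Where it says the series, first, only, none or still open, it means among the compounds named here.

In a functional assay on DU-145 cells (Homo sapiens) for inhibition, read by trypan blue exclusion, with a stated time of 96 h (on this read-out higher numbers stand for weaker inhibition of growth and lower numbers for stronger inhibition of growth), compound 1 `COc1cc(/C=C(/SCc2ccc(Br)cc2)C(=O)c2ccc(C(=O)O)cc2)ccc1F` gives 1000 nM and compound 2 `O=C(O)c1ccc(C(=O)/C(=C\c2ccc(Cl)c([N+](=O)[O-])c2)SCc2ccc(Br)cc2)cc1` gives 500 nM and these two values lie within the usual scatter of each other. Compound 3 `CSc1ccc(/C=C(/SCc2ccc(Br)cc2)C(=O)c2ccc(C(=O)O)cc2)cc1` differs from compound 2 at one place 4-(methylsulfanyl)phenyl in place of 4-chloro-3-nitrophenyl on a double-bonded chain carbon bound to a double-bonded chain carbon with 4-(methylsulfanyl)phenyl in place of 4-chloro-3-nitrophenyl on a double-bonded chain carbon bound to a double-bonded chain carbon. Going by the values given here, the one measured change at that place is a 2.0-fold lower number from compound 1 to compound 2 (0.30 log units; within the scatter) and it stays within the scatter, so no step beyond the scatter is expected. In this assay the expected change is a 1.4-fold higher number from compound 2 to compound 3 (0.15 log units; within the scatter) and this remains only an estimate. Compound 3 is therefore estimated at 700 nM with an expected range of 250 nM to 2000 nM for now.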

Compound 3, concentration for 50% growth inhibition: 10000 nM
For compound 3 the middle estimate is 14-fold (1.15 log units) below the measured one; the measured number lies above the stated range.
By their numbers in this assay, from the lowest: compounds 2 and 1 (each within the scatter of the next); then compound 3.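

In this assay the group at this place clearly matters: 4-(methylsulfanyl)phenyl in place of 4-chloro-3-nitrophenyl gives a 20-fold higher number from compound 2 to compound 3 (1.30 log units; beyond the scatter) and in place of 4-fluoro-3-methoxyphenyl gives a 10-fold higher number from compound 1 to compound 3 (1.00 log units; beyond the scatter) with weaker inhibition of growth in both steps. Both steps lie beyond the scatter, which the earlier swap at this place did not, so these substituted phenyl groups are not interchangeable here. Nothing available gives a reason for this loss. Still open, from the compounds shown here alone, is how a phenyl group carrying an amine or a carboxylic acid would behave at this place.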